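Taking one methoxy off a tightly bound compound

The compounds below may be only part of what the source reports. "The series", "measured", "known", "first", "only" and "open" are said of these compounds alone.

For the measured compounds named here, in an ADME assay on a cell-free system (plasma, Homo sapiens) for protein binding, read by LC-MS, with a stated time of 5 h, tested at 5 uM, compound 1 `COc1ccc(S(=O)(=O)N2CCCC[C@H]2C(=O)O[C@@H](Cc2c(Cl)c[n+]([O-])cc2Cl)c2ccc(OC(F)F)c(OCC3CC3)c2)cc1C(=O)N(C)C` gives 99.8% and so has the smaller free share of the two compounds measured so far. Compound 2 `Cn1cnc(S(=O)(=O)N2CCS[C@H]2C(=O)O[C@@H](Cc2c(Cl)c[n+]([O-])cc2Cl)c2ccc(OC(F)F)c(OCC3CC3)c2)c1` gives 98.5% and the gap between these two values lies beyond the usual scatter. Close to the top of this scale, small shifts in the percentage matter, since the free share is what changes noticeably. Compound 2 differs from compound 1 in more than one place, so that pair cannot show the effect of any single change.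

Compound 3 `CN(C)C(=O)c1cccc(S(=O)(=O)N2CCCC[C@H]2C(=O)O[C@@H](Cc2c(Cl)c[n+]([O-])cc2Cl)c2ccc(OC(F)F)c(OCC3CC3)c2)c1` is compound 1 with hydrogen in place of methoxy on an aromatic carbon, ortho to a dimethylcarbamoyl group and para to a large group. Going by the values given here, no measured pair shows this change alone, so the expectation starts from compound 1 at 99.8% with everything else kept the same. A slightly larger free share is expected, with no step beyond the scatter. The expected change is a 1.5-fold higher unbound fraction from compound 1 to compound 3 (0.18 log units; within the scatter) and stays within the usual scatter. Compound 3 is estimated at 99.7% (expected range 99.2% to 99.9%).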

Compound 3, plasma protein binding: 99.9%
The estimate for compound 3 lay 3.0-fold (0.48 log units) (unbound fraction) above the measured number; measured number inside the range.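

In this assay, for the compounds shown here, the swap of methoxy for hydrogen on this aromatic carbon, ortho to a dimethylcarbamoyl group and para to a large group, gives a 2.0-fold lower unbound fraction from compound 1 to compound 3 (0.30 log units; within the scatter) and so, in the first comparison that isolates a single change, shows no shift that can be told apart from the ordinary spread of repeated measurements. Losing the methoxy, with its 2 heavy atoms and 1 hydrogen-bond acceptor, therefore leaves the very tight plasma protein binding in place as far as this read-out can tell, and the methoxy is not needed for it. No measurement at hand bears on why this position responds so little to the swap.

Still open, on these data alone, is whether a different group on the same aromatic carbon, such as a carboxylic acid, an amine or a longer alkoxy chain, would move the free share by more than the scatter. The single swap shown also cannot tell whether hydrogen in place of methoxy would read the same way on another core.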